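The compounds below may be only part of what the source reports. "The series", "measured", "known", "first", "only" and "open" are said of these compounds alone.

Compound 1 `COc1ccc2c(=O)cc(Cc3ccncc3)oc2c1`: in an assay on V79MZh cells for inhibition of cytochrome P450 11B2, mitochondrial (Homo sapiens), with a stated time of 30 min (a higher number here means a weaker inhibitor, a lower number a stronger inhibitor), compound 1 gives > 5000 nM, which is a limit of the assay (the limit of > 5000 nM in this assay, at which 1 of the 3 values shown sits).
Compound 2 `O=c1cc(Cc2ccncc2)oc2cc(F)ccc12`: compound 2 gives 643 nM.
Compound 3 `O=c1c(Cn2ccnc2)coc2cc(F)ccc12`: compound 3 gives 214 nM.

Among the two numbers shown, compound 3 has the lower one; the nearest is compound 2, whose number is higher, and the gap is beyond the usual scatter.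

Compound 4 `O=c1c(Cc2cccnc2)coc2cc(F)ccc12` differs from compound 3 in one place: pyridin-3-yl in place of 1H-imidazol-1-yl on a saturated chain carbon bound to an aromatic carbon. For the measured compounds named here, the only measured step, an at least 7.7-fold lower number from compound 1 to compound 2 (0.89 log units; beyond the scatter), concerns a different place on the shared core and so does not bear on this change. Compound 4 is therefore expected to give 450 nM, with a range from 120 nM to 1800 nM. The expected step is a 2.1-fold higher number from compound 3 to compound 4 (0.32 log units; beyond the scatter), a modest move toward a weaker inhibitor.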

Compound 4, half-maximal inhibitory concentration: > 10000 nM
Compound 4: a limit, no number; the forecaster's own chance of this, stated with the estimate: 5%; middle value at least 22-fold (1.34 log units) from the limit.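

In this assay pyridin-3-yl in place of 1H-imidazol-1-yl gives an at least 46-fold higher number from compound 3 to compound 4 (1.66 log units; beyond the scatter), so the ring on this saturated chain carbon bound to an aromatic carbon can decide much of the inhibition. Compound 4 gives a limit of the assay, not a number: the limit of > 10000 nM in this assay, at which 1 of the 4 values shown sits. Two aromatic rings that both carry nitrogen are therefore not interchangeable at this place on the shared core.

Going by these compounds, how much weaker compound 4 truly is stays open. So does whether a 1H-1,2,4-triazol-1-yl group or a simple amine at this place would behave like the imidazole or like the pyridine.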